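Thiazolylmethyl Ether Replacing a Trifluoroethyl Ether in a Pyridinone Series

This account rests on a few compounds, and the source may have more. Where it says the series, first, only, none or still open, it means among the compounds named here.

Measured so far:
Compound 1, `N#Cc1ccccc1-c1cc(-c2cc(Cl)cc(OCCC(F)(F)F)c2)c(=O)n(-c2cccnc2)c1`: 4 10^-6 cm/s
Compound 2, `Cn1cc(-c2cc(-c3cc(Cl)cc(OCCC(F)(F)F)c3)c(=O)n(-c3cccnc3)c2)c(=O)[nH]c1=O`: 2.26 10^-6 cm/s

In an ADME assay for permeability, using PAMPA, in phosphate buffer, with a stated time of 18 h, at pH 7.4 (a higher number here means that the compound crosses the layer faster, a lower number that the compound crosses the layer more slowly), compound 1 gives 4 10^-6 cm/s and compound 2 gives 2.26 10^-6 cm/s. Within the data shown here, the one step between them, a 1.8-fold lower number from compound 1 to compound 2 (0.25 log units; within the scatter), concerns an exchange on the shared core remote from the ether side chain. Compound 2 thus holds the lower of the two numbers, yet its distance from compound 1 lies within the scatter, so no order between the two can be claimed.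

The unmeasured compound 3, `Cn1cc(-c2cc(-c3cc(Cl)cc(OCc4scnc4C(F)(F)F)c3)c(=O)n(-c3cccnc3)c2)c(=O)[nH]c1=O`, differs from compound 2 only at the ether: a group of 9 heavy atoms (4 carbon, 1 nitrogen, 3 fluorine, 1 sulfur; one five-membered aromatic ring with 2 hetero atoms) in place of a group of 5 heavy atoms (2 carbon, 3 fluorine; no ring), on a saturated chain carbon bound to an oxygen on an aromatic ring. Among the measured compounds shown here, no measured step touches this position, so the expectation rests on the size of the one step seen, which was itself within the scatter. The step from compound 2 to compound 3 is therefore expected to stay within the scatter, estimated as a 1.2-fold lower number from compound 2 to compound 3 (0.08 log units; within the scatter). For compound 3 the estimated result in this assay is 1.9 10^-6 cm/s, with a range from 0.8 10^-6 cm/s to 4.5 10^-6 cm/s.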

Compound 3, apparent permeability in the ADME assay: 1.16 10^-6 cm/s
The estimate for compound 3 lay 1.6-fold (0.21 log units) above the measured number; the measured number falls inside the stated range.
By their numbers in the ADME assay, from the lowest: compounds 3, 2 and 1 (each within the scatter of the next, the first and the last beyond it).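

Among these compounds, the step at this place, a 1.9-fold lower number from compound 2 to compound 3 (0.29 log units; within the scatter), is the first measured at the saturated chain carbon bound to an oxygen on an aromatic ring, and in the ADME assay it still does not separate the two compounds beyond the scatter. The earlier step, an exchange elsewhere on the shared core, said nothing about this position, whereas this one shows that the 2,2,2-trifluoroethyl group can give way to a group with one five-membered aromatic ring without a step beyond the scatter on this read-out. The same change does register, though modestly, beyond the scatter in a physicochemical assay for solubility, using the shake flask method, with a stated time of 48 h, at pH 6.5; on this read-out lower numbers stand for lower solubility and higher numbers for higher solubility: the measured solubility of compound 2, 57 ug/mL, and of compound 3, 24.8 ug/mL, a 2.3-fold lower number (0.36 log units; beyond the scatter). In the physicochemical assay compound 2 gives 57 ug/mL and compound 3 gives 24.8 ug/mL.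

The compounds shown leave open whether the difference in solubility goes with the five-membered aromatic ring itself or with the trifluoromethyl group it carries, as the two enter together. They also leave open how a plain phenyl ring or a simple methyl group at the same place would read in the ADME assay and in the physicochemical assay.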